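Sulfamoyl to methanesulfonamido: compound 3 to compound 4

The compounds below may be only part of what the source reports. "The series", "measured", "known", "first", "only" and "open" are said of these compounds alone.

Measured in a physicochemical assay for solubility, read by HPLC, using the shake flask method, measured as kinetic solubility, with a stated time of 20 h, at pH 6.5, tested at 200 uM; on this read-out lower numbers stand for lower solubility and higher numbers for higher solubility:
compound 1 `C[C@@H](CO)NS(=O)(=O)c1cccc(-c2ccc3nccc(-c4ccncc4)c3n2)c1` gives 50000 nM
compound 2 `O=S(=O)(NCC1COC1)c1cccc(-c2ccc3nccc(-c4ccncc4)c3n2)c1` gives 20000 nM
compound 3 `NS(=O)(=O)c1cccc(-c2ccc3nccc(-c4ccncc4)c3n2)c1` gives < 5000 nM (a limit)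

Compound 3 has only a limit and no number (the limit of < 5000 nM in this assay, at which 1 of the 3 values shown sits). Compound 4 `CS(=O)(=O)Nc1cccc(-c2ccc3nccc(-c4ccncc4)c3n2)c1` carries methanesulfonamido in place of sulfamoyl on an aromatic carbon, meta to a large group (methanesulfonamido in place of sulfamoyl on an aromatic carbon). The nearest measured steps change the substituent on a sulfonamide nitrogen: a 2.5-fold lower number from compound 1 to compound 2 (0.40 log units; beyond the scatter), then an at least 10-fold lower number from compound 1 to compound 3 (1.00 log units; beyond the scatter), and an at least 4.0-fold lower number from compound 2 to compound 3 (0.60 log units; beyond the scatter). None of them exchanges sulfamoyl for methanesulfonamido, so they bear on this change only indirectly. No step beyond the scatter is expected in this assay, in either direction. The expected step is a number no lower from compound 3 to compound 4 (the limit leaves the size open). Compound 4 is estimated at 5000 nM (expected range 2000 nM to 15000 nM).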

Compound 4, solubility: 20000 nM
The estimate for compound 4 lay 4.0-fold (0.60 log units) below the measured number, and the stated range ends below it.
By their numbers in this assay, from the lowest: compounds 2 and 4 (each within the scatter of the next); then compound 1. At a limit, below all of these: compound 3.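

Methanesulfonamido is accepted on this aromatic carbon, and in this assay the change from sulfamoyl gives an at least 4.0-fold higher number from compound 3 to compound 4 (0.60 log units; beyond the scatter). The earlier steps shown here varied only the substituent on a sulfonamide nitrogen, yet this different group gives no change at the digits printed from compound 2 to compound 4 (within the scatter) and a 2.5-fold lower number from compound 1 to compound 4 (0.40 log units; beyond the scatter). Compound 3 stands at a limit: the limit of < 5000 nM in this assay, at which 1 of the 4 values shown sits.

From the compounds shown here alone, whether a longer chain in place of the methyl of methanesulfonamido would keep the number of compound 4 remains open. So does the outcome for an amine or a carboxylic acid on this aromatic carbon.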